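This account rests on a few compounds, and the source may have more. Where it says the series, first, only, none or still open, it means among the compounds named here.

Measured so far:
Compound 1: `O=[N+]([O-])c1ccccc1CNc1cccc2[nH]ncc12`, 17000 nM
Compound 2: `O=[N+]([O-])c1cc(Br)c(F)cc1CNc1cc(C(F)(F)F)cc2[nH]ncc12`, 1460 nM

In an assay for inhibition of Tryptophan 2,3-dioxygenase (Homo sapiens), with stated times of 10 min and 60 min (a higher number here means a weaker inhibitor, a lower number a stronger inhibitor), compound 1 gives 17000 nM, the highest of the two numbers, making it the weaker inhibitor of the pair. Compound 2 gives 1460 nM in this assay, a lower number, and the gap lies beyond the usual scatter. Compound 2, however, differs from compound 1 in several places at once, so the share of any single added group cannot be separated out.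

Compound 3, `O=[N+]([O-])c1ccccc1CNc1cc(Br)cc2[nH]ncc12`, keeps the rest of compound 1 unchanged and differs in just one place: bromo in place of hydrogen on an aromatic carbon. For the measured compounds named here, no pair of measured compounds differs only in this way, so no direct step is known. Since compound 2 carries added groups on the shared core and gives the lower number, a small to moderate lowering is expected from this change. Compound 3 is estimated at 6000 nM, with a range from 2000 nM to 17000 nM. This expectation corresponds to an estimated step of a 2.8-fold lower number from compound 1 to compound 3 (0.45 log units; beyond the scatter).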

Compound 3, half-maximal inhibitory concentration: 39000 nM
Estimate against measurement, compound 3: 6.5-fold (0.81 log units) below; the measured number lies above the stated range.
By their numbers in this assay, from the lowest: compound 2; then compound 1; then compound 3.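

In this assay, for the compounds shown here, this is the first change seen in isolation: bromo in place of hydrogen on the shared core, para to a fused ring, gives a 2.3-fold higher number from compound 1 to compound 3 (0.36 log units; beyond the scatter), so this inhibitor is modestly weaker. Compound 2 could not show this, since it differs from compound 1 in several places at once. Here, a single added atom at one position moves the number upward, so a heavier substituent at this position does not automatically bring a lower number. No measurement at hand bears on why the bromo has this effect.

As far as these compounds go, what remains open is whether the trend holds for other groups at this same position, such as fluoro, methoxy or an amine. It is also unclear which of the several differences in compound 2 accounts for its lower number.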